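Clearance Outlook After Replacing Piperidin-4-yl With 4-Aminobutyl

The source may report more compounds than this note shows. Statements on the series, on what has been measured and on what is new or still open speak of the compounds shown alone.

Compound 1 `O=S(=O)(c1ccc([C@H]2CC[C@]3(CC2)OOC2(O3)C3CC4CC(C3)CC2C4)cc1)N1CCNCC1`: 16 mL.min-1.g-1
Compound 2 `c1cc([C@H]2CC[C@]3(CC2)OOC2(O3)C3CC4CC(C3)CC2C4)ccc1OC1CCNCC1`: 15 mL.min-1.g-1

In an ADME assay on microsomes from liver (Homo sapiens) for metabolic stability, read by LC-MS, tested at 1 uM (on this read-out higher numbers stand for fast clearance and lower numbers for slow clearance), compound 2 gives 15 mL.min-1.g-1, the lowest of the two numbers measured, though its separation from compound 1 is within the scatter. For the measured compounds named here, the one measured step, a 1.1-fold lower number from compound 1 to compound 2 (0.03 log units; within the scatter), replaced one group on the shared core with another and left the read-out essentially unchanged.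

Compound 3 `NCCCCOc1ccc([C@H]2CC[C@]3(CC2)OOC2(O3)C3CC4CC(C3)CC2C4)cc1` differs from compound 2 by 4-aminobutyl in place of piperidin-4-yl on an oxygen on an aromatic ring. Going by the values given here, nothing measured here bears directly on this change: the only step recorded concerns a different position and a different pair of groups. Among the compounds with values here, with no comparable step to lean on, the expectation for compound 3 is a value close to that of compound 2, and the estimated step of a 1.2-fold higher number from compound 2 to compound 3 (0.08 log units; within the scatter) is not expected to exceed the scatter. Compound 3 is therefore estimated at 18 mL.min-1.g-1, with a range from 9 mL.min-1.g-1 to 36 mL.min-1.g-1.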

Compound 3, intrinsic clearance in microsomes: < 7 mL.min-1.g-1
Compound 3 was reported as a limit (the forecaster's own chance of this, stated with the estimate: 5%); middle value at least 2.5-fold (0.41 log units) away from the limit.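

In this assay, 4-aminobutyl in place of piperidin-4-yl on the oxygen gives an at least 2.1-fold lower number from compound 2 to compound 3 (0.33 log units; beyond the scatter), so this position responds to the change in a way that the earlier step, which stayed within the scatter, did not show. The value of compound 3 is a limit of the assay and not a number: the limit of < 7 mL.min-1.g-1 in this assay, at which 1 of the 3 values shown sits.

The same holds when 4-aminobutoxy replaces (piperazin-1-yl)sulfonyl, with an at least 2.2-fold lower number from compound 1 to compound 3 (0.35 log units; beyond the scatter), whereas (piperidin-4-yl)oxy in compound 2 stayed within the scatter of that group.

The compounds shown cannot separate the loss of the ring from the length of the chain or the type of amine. An aminopropyl chain, an aminopentyl chain or a methylaminobutyl group on the same oxygen would help to tell these apart.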